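Hydroxymethyl to Tertiary Alcohol on the Cyclohexyl Ring

A few compounds are considered here, and "the series" means these few. Any claim that something is new, unique, unknown or untested is made for them only; others in the source may bear on it.

Measured compounds:
- compound 1, `Cc1cc2oc(N3CCC(C(=O)N[C@H]4CCC[C@H](CO)C4)CC3)nc2cc1Cl`, 65000 nM
- compound 2, `Cc1cc2oc(N3CCC(C(=O)N[C@H]4CC[C@@](O)(C(F)(F)F)CC4)CC3)nc2cc1Cl`, > 100000 nM

Of the compounds shown here, two sharing one core have been tested in a physicochemical assay for solubility, read by nephelometry, in phosphate buffer, at pH 7.4; on this read-out lower numbers stand for lower solubility and higher numbers for higher solubility. Compound 1, carrying a hydroxymethyl group on its cyclohexyl ring, gives 65000 nM in this assay. For compound 2 the result is a limit of the assay rather than a number, > 100000 nM; this is the limit of > 100000 nM in this assay, at which 1 of the 2 values shown sits. Among the compounds with values here, compound 1 therefore stands as the only compound of the pair with a definite number, and no step between two measured compounds is available to guide the next change.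

The unmeasured compound 3, `Cc1cc2oc(N3CCC(C(=O)N[C@H]4CCC[C@H](C(C)(C)O)C4)CC3)nc2cc1Cl`, differs from compound 1 in one place: 1-hydroxy-1-methylethyl in place of hydroxymethyl on a saturated ring carbon. Within the data shown here, with no measured step of this kind to draw on, the step of a 1.3-fold lower number from compound 1 to compound 3 (0.11 log units; within the scatter) is expected to stay within the usual scatter of repeated measurements, with no clear direction. Compound 3 is accordingly estimated to give about 50000 nM in this assay, most likely between 20000 nM and 100000 nM.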

Compound 3, solubility: 58000 nM
Compound 3: the middle estimate sits 1.2-fold (0.06 log units) below what was measured; low and high end bracket the measured number.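

In this assay, putting 1-hydroxy-1-methylethyl in place of hydroxymethyl on a saturated ring carbon gives a 1.1-fold lower number from compound 1 to compound 3 (0.05 log units; within the scatter), so the two compounds cannot be told apart on this read-out. Within the data shown here, this is the first step between measured compounds that differ in only one place, and it shows that this ring carbon can carry a group of 4 heavy atoms instead of 2, with the same count of hydrogen-bond donors and acceptors and no net charge, while the reading stays within the scatter. Nothing measured here gives a reason for this outcome, so it stands as an observation about one change at one place.

A single step cannot show how far this holds, and it leaves open whether a group of a different kind at this ring carbon, such as an amine, a carboxylic acid or a longer chain ending in a hydroxyl, would move the number beyond the scatter. It also leaves open whether the same swap would read the same way on a different core, or on a ring carrying its group at another place.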